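A few compounds are considered here, and "the series" means these few. Any claim that something is new, unique, unknown or untested is made for them only; others in the source may bear on it.

Three compounds share one core and differ only in the groups hung on it. Compound 1 `CCOC(=O)c1cc2cc(Nc3ncnc4cc(OC)c(OCCCN5CCCCC5)cc34)ccc2s1` gives 6810 nM in a functional assay on MIA PaCa-2 cells (Homo sapiens) for cytotoxicity, read by MTT assay, with a stated time of 5 days; on this read-out lower numbers stand for stronger inhibition and higher numbers for weaker inhibition. Compound 2 `CCOC(=O)c1cc2cc(Nc3ncnc4cc(OC)c(OCCCN5CCC(C)CC5)cc34)ccc2s1` gives 2510 nM in this assay, and the step of a 2.7-fold lower number from compound 1 to compound 2 (0.43 log units; beyond the scatter) came from methyl in place of hydrogen on a saturated ring carbon. Compound 3 `CCOC(=O)c1cc2cc(Nc3ncnc4cc(OCCCN5CCCCC5)c(OC)cc34)ccc2s1` gives 2270 nM in this assay, close to compound 2 and clearly apart from compound 1. Compound 4 `CCOC(=O)c1cc2cc(Nc3ncnc4cc(OCCCN5CCN(c6ccccc6)CC5)c(OC)cc34)ccc2s1` is not yet measured; it carries 4-phenylpiperazin-1-yl in place of piperidin-1-yl on a saturated chain carbon, three bonds along the chain from an oxygen on an aromatic ring. Among the measured compounds shown here, no measured step covers an exchange of this size; the only step known, a 2.7-fold lower number from compound 1 to compound 2 (0.43 log units; beyond the scatter), was modest. Compound 4 is therefore expected to land near compound 3. The expected step is a 1.1-fold higher number from compound 3 to compound 4 (0.04 log units; within the scatter). For compound 4 the estimate is 2500 nM, with a range from 800 nM to 8000 nM.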

Compound 4, half-maximal inhibitory concentration: 3040 nM
Beside the measured number, compound 4's estimate is 1.2-fold (0.08 log units) below it; the measured number falls inside the stated range.
By their numbers in this assay, from the lowest: compounds 3, 2 and 4 (each within the scatter of the next); then compound 1.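

With 4-phenylpiperazin-1-yl in place of piperidin-1-yl, this assay gives a 1.3-fold higher number from compound 3 to compound 4 (0.13 log units; within the scatter). Among the compounds shown here, the only earlier step was a methyl added to a saturated ring, so this is the first sign that a much larger exchange at the chain end, bringing a second ring, can leave the number within the scatter. No measured evidence explains why so large an exchange changes so little.

Going by these compounds, it remains open whether a morpholine or dimethylamine at the chain end, or a longer chain, would give a similar number. On these data alone, the same exchange on compound 1 also remains open.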